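Replacing phenyl with ethyl on a ring amine nitrogen

A few compounds are considered here, and "the series" means these few. Any claim that something is new, unique, unknown or untested is made for them only; others in the source may bear on it.

Measured in a functional assay on HeLa cells (Homo sapiens) for antiproliferative activity, read by sulforhodamine B assay, with a stated time of 48 h; on this read-out lower numbers stand for stronger inhibition and higher numbers for weaker inhibition:
- Compound 1 `COc1ccc(C[C@@H](O)/C=C/C=C/C(=O)N2CCCCC2)cc1OC`: 14100 nM
- Compound 2 `COc1ccc(C[C@@H](O)/C=C/C=C/C(=O)N2CCN(C)CC2)cc1OC`: 16500 nM
- Compound 3 `COc1ccc(C[C@@H](O)/C=C/C=C/C(=O)N2CCN(c3ccccc3)CC2)cc1OC`: 9750 nM

The three compounds cannot be told apart on these numbers. Compound 3, at 9750 nM, lies within the scatter of both compound 1 and compound 2.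

Compound 4 `CCN1CCN(C(=O)/C=C/C=C/[C@H](O)Cc2ccc(OC)c(OC)c2)CC1` carries ethyl in place of phenyl on an amine nitrogen in a ring. Among the measured compounds shown here, two measured steps bear on this change. The more direct one, at the same place, is a 1.7-fold lower number from compound 2 to compound 3 (0.23 log units; within the scatter), where phenyl replaced methyl. The other is a 1.2-fold higher number from compound 1 to compound 2 (0.07 log units; within the scatter), made by exchanging piperidin-1-yl for 4-methylpiperazin-1-yl. Both stayed within the scatter. Ethyl, like methyl, has no ring, so compound 2 at 16500 nM is the nearest guide.

The estimated step is a 1.5-fold higher number from compound 3 to compound 4 (0.19 log units; within the scatter), and no change beyond the scatter is expected. For compound 4 the expected value is 15000 nM, with an estimated range from 8000 nM to 28000 nM.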

Compound 4, half-maximal inhibitory concentration: 11700 nM
Compound 4: middle estimate off by 1.3-fold (0.11 log units), on the high side; low and high end bracket the measured number.
By their numbers in this assay, from the lowest: compounds 3, 4, 1 and 2 (each within the scatter of the next).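

In this assay, the exchange at this amine nitrogen in a ring gave a 1.2-fold higher number from compound 3 to compound 4 (0.08 log units; within the scatter), so phenyl, with its six-membered aromatic ring, and ethyl, with no ring, cannot be told apart at this place. The two other steps to compound 4 also stay small, with a 1.4-fold lower number from compound 2 to compound 4 (0.15 log units; within the scatter) for ethyl against methyl and a 1.2-fold lower number from compound 1 to compound 4 (0.08 log units; within the scatter) for 4-ethylpiperazin-1-yl against piperidin-1-yl, so a ring-bearing group and two short chains on this nitrogen, and the piperidin-1-yl amide without one, all read alike. No measurement is at hand that would explain this sameness.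

On these data alone, what remains open is whether any group on this nitrogen can move the number beyond the scatter. A benzyl group or a carboxylic acid on a longer chain there would test this.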